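A Ring Exchange on the Side Chain of Compound 1

This account rests on a few compounds, and the source may have more. Where it says the series, first, only, none or still open, it means among the compounds named here.

Compound 1 `CC(Sc1nc2c(cnn2C)c(=O)n1-c1ccccc1)c1cccc(F)c1` stands lowest of the two numbers measured in an assay on isolated protein for inhibition of retinal dehydrogenase 2 (Homo sapiens) (on this read-out higher numbers stand for weaker inhibition and lower numbers for stronger inhibition), where compound 1 gives 110 nM. Compound 2 `C#Cc1ccc(-n2c(SC(C)c3ccccc3)nc3c(cnn3C)c2=O)cc1` gives 800 nM in this assay, a gap beyond the usual scatter. Compound 3 `CC(Sc1nc2c(cnn2C)c(=O)n1-c1ccccc1)c1cncnc1` has not yet been measured; it differs from compound 1 in one place: pyrimidin-5-yl in place of 3-fluorophenyl on a saturated chain carbon bound to a saturated chain carbon and a sulfur. Within the data shown here, no measured pair isolates this exchange, so its effect is not known from the data. The expected step, a 3.6-fold higher number from compound 1 to compound 3 (0.56 log units; beyond the scatter), is a modest one toward weaker inhibition. Compound 3 is estimated at 400 nM, with a range from 120 nM to 1500 nM.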

Compound 3, half-maximal inhibitory concentration: 380 nM
Estimate against measurement, compound 3: 1.1-fold (0.02 log units) above, within the range that was stated.
By their numbers in this assay, from the lowest: compound 1; then compound 3; then compound 2.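

In this assay, among these compounds, the exchange of 3-fluorophenyl for pyrimidin-5-yl gives a 3.5-fold higher number from compound 1 to compound 3 (0.54 log units; beyond the scatter), the first direct reading of a change at this position. The position therefore tolerates a ring with hetero atoms at a modest cost, and the 1-(pyrimidin-5-yl)ethyl compound stays measurable on this read-out. No measurement here bears on why the number rises. Among the compounds shown here, the single exchange does not separate the loss of the fluorine from the entry of the ring nitrogens. On these data alone, how a plain phenyl or a pyridin-3-yl ring would fare at this position remains open.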